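The compounds below may be only part of what the source reports. "The series", "measured", "known", "first", "only" and "open" are said of these compounds alone.

Measured compounds in a functional assay on thoracic aorta (Rattus norvegicus, strain Wistar), with a stated time of 15 min; on this read-out higher numbers stand for an effect only at larger amounts of compound and lower numbers for an effect already at smaller amounts:
compound 1 `Cc1ccc(OCc2ccccc2)c(C(C)NC(=O)NS(=O)(=O)c2ccc(Cl)cc2)c1`: compound 1 gives 65300 nM.
compound 3 `CC(NC(=O)NS(=O)(=O)c1ccc(Cl)cc1)c1ccccc1OCc1ccccc1`: compound 3 gives 157000 nM.
compound 2 `COc1ccc(OC)c(CNC(=O)NS(=O)(=O)c2ccc(C)cc2)c1`: for compound 2 the assay gives only a limit, > 300000 nM.

From compound 1 to compound 3 the change is hydrogen in place of methyl on an aromatic carbon, and the step is a 2.4-fold higher number from compound 1 to compound 3 (0.38 log units; beyond the scatter). The value of compound 2 is a limit of the assay, not a number; (the limit of > 300000 nM in this assay, at which 1 of the 3 values shown sits). How the core of compound 2 differs from the core of compound 1 is not broken down here.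

Compound 4 `COc1ccc(OC)c(CNC(=O)NS(=O)(=O)c2ccccc2)c1` has not been measured in this assay. From compound 2 to compound 4 the change is hydrogen in place of methyl on an aromatic carbon. This is the same kind of change as that from compound 1 to compound 3, but the surroundings differ: there the methyl sat meta to a large group and para to a benzyloxy group, here it sits para to a large group.

In this assay the step from compound 2 to compound 4 is expected to be a step that the limit leaves unreadable from compound 2 to compound 4. This rests on compound 1, whose step a 2.4-fold higher number from compound 1 to compound 3 (0.38 log units; beyond the scatter) went to a higher number when the methyl was removed. It also rests on compound 2, whose value > 300000 nM is already a limit. Compound 4 is therefore expected near 600000 nM, between 250000 nM and 2000000 nM, and most likely the assay will again report only a limit.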

Compound 4, half-maximal effective concentration: > 300000 nM
Compound 4: no number, only a limit; the forecaster's own chance of this, stated with the estimate: 85%; the middle value lies beyond the limit too.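

In this assay compound 4 gives > 300000 nM as a limit of the assay and not a number. No step can be read between compound 2 and compound 4, because both stand at the same limit: the limit of > 300000 nM in this assay, at which 2 of the 4 values shown sit.

The compounds shown leave open whether going from 4-methylphenyl to phenyl on the shared core of compound 2 and compound 4 shifts the read-out at all.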